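A few compounds are considered here, and "the series" means these few. Any claim that something is new, unique, unknown or untested is made for them only; others in the source may bear on it.

Compound 1 (`O=C(/C=C/c1cccc2ccccc12)c1cccc(NC(=O)c2cc(-c3ccncc3)n[nH]2)c1`), compound 2 (`O=C(/C=C/c1ccc(F)cc1)c1cccc(NC(=O)c2cc(-c3ccncc3)n[nH]2)c1`) and compound 3 (`COc1ccc(/C=C/C(=O)c2cccc(NC(=O)c3cc(-c4ccncc4)n[nH]3)c2)cc1`) share one core and differ only in the aromatic group on a double-bonded chain carbon bound to a double-bonded chain carbon. In a functional assay, read by spectrophotometry, tested at 100 uM (a higher number here means a weaker inhibitor, a lower number a stronger inhibitor), compound 1 gives 64500 nM and compound 2 gives 56000 nM, while compound 3 gives 38400 nM as its value. Compound 3 cannot be separated from the other two, as the steps show: a 1.7-fold lower number from compound 1 to compound 3 (0.23 log units; within the scatter) and a 1.5-fold lower number from compound 2 to compound 3 (0.16 log units; within the scatter) are the two that reach it. The remaining step is a 1.2-fold lower number from compound 1 to compound 2 (0.06 log units; within the scatter) and it tells the same story.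

Compound 4 (`COc1cc(/C=C/C(=O)c2cccc(NC(=O)c3cc(-c4ccncc4)n[nH]3)c2)cc(OC)c1OC`) has 3,4,5-trimethoxyphenyl in place of 4-methoxyphenyl, and the change counts as 3,4,5-trimethoxyphenyl in place of 4-methoxyphenyl on a double-bonded chain carbon bound to a double-bonded chain carbon in full. Within the data shown here, no measured step tests this exact exchange, so the three changes of the same group are the only guide. All three stayed within the scatter, so no step beyond the scatter is expected in this assay here. The estimated step is a 1.1-fold higher number from compound 3 to compound 4 (0.04 log units; within the scatter) on this reasoning. Among the measured compounds shown here, for compound 4 the estimated value is 42000 nM with an expected range from 18000 nM to 95000 nM (a wide one, since only three compounds inform it).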

Compound 4, half-maximal inhibitory concentration: 54500 nM
The estimate for compound 4 lay 1.3-fold (0.11 log units) below the measured number, within the range that was stated.
By their numbers in this assay, from the lowest: compounds 3, 4, 2 and 1 (each within the scatter of the next).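

Swapping 4-methoxyphenyl for 3,4,5-trimethoxyphenyl raises the group from 8 to 12 heavy atoms and from 1 to 3 hydrogen-bond acceptors, yet in this assay this gives a 1.4-fold higher number from compound 3 to compound 4 (0.15 log units; within the scatter). The same group gives a 1.0-fold lower number from compound 2 to compound 4 (0.01 log units; within the scatter) and a 1.2-fold lower number from compound 1 to compound 4 (0.07 log units; within the scatter), so all four aromatic groups on a double-bonded chain carbon bound to a double-bonded chain carbon now lie within the scatter of one another, even with this added bulk of methoxy groups. No measurement offered here explains this flat result.

On these data alone, all four groups are aromatic rings of carbon only, so it remains open whether an amine or a carboxylic acid at this place would give a step beyond the scatter. As far as these compounds go, the shared core is also the same throughout, so the effect of changing it remains open too.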